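Replacing 4-methoxypyridin-2-yl with pyrazin-2-yl: an expected solubility

The source may report more compounds than this note shows. Statements on the series, on what has been measured and on what is new or still open speak of the compounds shown alone.

Compound 1 (`FC(F)(F)Oc1ccc(-c2nc3cnc(Nc4ccccn4)cc3[nH]2)cc1`): 26000 nM 
Compound 2 (`COc1ccnc(Nc2cc3[nH]c(-c4cccc(C(F)(F)F)c4)nc3cn2)c1`): < 5000 nM (a limit)

In a physicochemical assay for solubility, using the shake flask method, measured as kinetic solubility, with a stated time of 20 h, at pH 2 (on this read-out lower numbers stand for lower solubility and higher numbers for higher solubility), compound 1 gives a measured number (26000 nM). Compound 2 gives only a limit of the assay (< 5000 nM) and no number. For the measured compounds named here, these two compounds do not form a step that differs in one place, so no measured step is available as a guide.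

Compound 3 (`FC(F)(F)c1cccc(-c2nc3cnc(Nc4cnccn4)cc3[nH]2)c1`) has pyrazin-2-yl in place of the 4-methoxypyridin-2-yl of compound 2, on a nitrogen on an aromatic ring (pyrazin-2-yl in place of 4-methoxypyridin-2-yl on a nitrogen on an aromatic ring). The data do not show what this exchange does in this assay on its own. The expectation therefore starts from the limit of compound 2 (< 5000 nM), which is a limit and nothing firmer.

The estimated change (a step that the limit leaves unreadable from compound 2 to compound 3) is expected to stay within the usual scatter, with no clear direction. Compound 3 is expected at about 4000 nM on this read-out, with an estimated range from 1200 nM to 15000 nM in the measurement to come.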

Compound 3, solubility: 155000 nM
For compound 3 the middle estimate is 39-fold (1.59 log units) below the measured one, and the stated range ends below it.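

In this assay, putting pyrazin-2-yl in place of 4-methoxypyridin-2-yl on a nitrogen on an aromatic ring gives an at least 31-fold higher number from compound 2 to compound 3 (1.49 log units; beyond the scatter). For the compounds shown here, the earlier compounds offered no step that differs in one place, so this is the first measured sign that the group on this nitrogen can move this read-out beyond the scatter, and here it moves it upward. Compound 2 has only a limit and no number, which makes the size of the step a minimum and leaves its true size unknown: the limit of < 5000 nM in this assay, at which 1 of the 3 values shown sits.

Compound 1 differs from compound 3 in more than one place, so the compounds shown cannot tell whether the step comes from the departure of the methoxy group, from the change from one ring hetero atom to two, or from both together. Also open, on these data alone, is how the read-out would respond on this same nitrogen to a plain pyridin-2-yl group with the 3-(trifluoromethyl)phenyl group kept in place, to a pyrimidin-2-yl group, or to a pyridine ring carrying an amine.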